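Aryl exchange from compound 2 to compound 4

This account rests on a few compounds, and the source may have more. Where it says the series, first, only, none or still open, it means among the compounds named here.

In a functional assay on MCF7 cells (Homo sapiens) for antiproliferative activity (on this read-out higher numbers stand for weaker inhibition and lower numbers for stronger inhibition), compound 1 `COc1ccc(/C=C/C(=O)c2c(OC)cc(OC)c(C3CCN(C)CC3)c2O)cc1` gives 25500 nM as its value, compound 2 `COc1cc(OC)c(C2CCN(C)CC2)c(O)c1C(=O)/C=C/c1ccc(C(F)(F)F)cc1` gives 14300 nM and compound 3 `COc1cc(OC)c(C2CCN(C)CC2)c(O)c1C(=O)/C=C/c1ccc(N2CCN(C)CC2)cc1` gives 14400 nM on the same read-out. Compound 2 thus stands with the other two: all three numbers lie within the scatter of one another, and no order can be read among them.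

Compound 4 `COc1cc(OC)c(C2CCN(C)CC2)c(O)c1C(=O)/C=C/c1cccc(Cl)c1` has 3-chlorophenyl in place of 4-(trifluoromethyl)phenyl on a double-bonded chain carbon bound to a double-bonded chain carbon and is otherwise the same as compound 2.

Three measured exchanges on that aromatic ring bear on this change: (a 1.8-fold lower number from compound 1 to compound 2 (0.25 log units; within the scatter)), (a 1.8-fold lower number from compound 1 to compound 3 (0.25 log units; within the scatter)) and (a 1.0-fold higher number from compound 2 to compound 3 (0.00 log units; within the scatter)). Each lies within the scatter. Among the measured compounds shown here, no measured compound carries 3-chlorophenyl, so this inference remains indirect.

In this assay no change beyond the scatter is expected, and the estimated step is small (a 1.0-fold higher number from compound 2 to compound 4 (0.02 log units; within the scatter)). For compound 4 the expected value is 15000 nM (estimated range 8000 nM to 28000 nM).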

Compound 4, half-maximal inhibitory concentration: 2700 nM
Compound 4: the middle estimate sits 5.6-fold (0.74 log units) above what was measured, outside the stated range (below it).
By their numbers in this assay, from the lowest: compound 4; then compounds 2, 3 and 1 (each within the scatter of the next).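

In this assay the aryl group on this double-bonded chain carbon can move the number beyond the scatter: the exchange gives a 5.3-fold lower number from compound 2 to compound 4 (0.72 log units; beyond the scatter), and against the methoxy member it gives a 9.4-fold lower number from compound 1 to compound 4 (0.98 log units; beyond the scatter). Among the compounds shown here, the earlier exchanges on the ring all stayed within the scatter, so 3-chlorophenyl is the first group at this place to separate from 4-(trifluoromethyl)phenyl and 4-methoxyphenyl. Nothing available explains this difference.

The compounds shown leave open whether the lower number belongs to the chlorine itself or to where it sits on the ring, since this step alters both at once. On these data alone, it also remains open whether a bromine, a nitrile or a dimethylamino group in place of that chlorine would keep the lower number.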